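A few compounds are considered here, and "the series" means these few. Any claim that something is new, unique, unknown or untested is made for them only; others in the source may bear on it.

Compound 1, `Cc1cccc(-c2noc(C3CN(S(=O)(=O)c4cccc(C)c4)C3)n2)c1`, is tested in an assay on HEK293 cells for negative allosteric modulation of metabotropic glutamate receptor 5 (Homo sapiens), read by FLIPR (a higher number here means a weaker inhibitor, a lower number a stronger inhibitor), where compound 1 gives 650 nM. Compound 2, `O=C(c1ccccc1F)N1CC(c2nc(-c3cccc(Cl)c3)no2)C1`, gives 670 nM in this assay, a number within the scatter of that of compound 1, so the two cannot be told apart on these figures. Compound 3, `Cc1ccc(S(=O)(=O)N2CC(c3nc(-c4cccc(C)c4)no3)C2)cc1`, is not yet measured; it carries 4-methylphenyl in place of 3-methylphenyl on a sulfonyl sulfur. With no comparable change among the measured pair to lean on, a small step is expected, if any, in either direction but most likely a slight weakening, and the estimated step from compound 1 to compound 3 in this assay is a 1.4-fold higher number from compound 1 to compound 3 (0.14 log units; within the scatter). Compound 3 is therefore expected to give about 900 nM, in a range from 300 nM to 3000 nM.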

Compound 3, half-maximal inhibitory concentration: 670 nM
The estimate for compound 3 lay 1.3-fold (0.13 log units) above the measured number; low and high end bracket the measured number.
By their numbers in this assay, from the lowest: compounds 1, 2 and 3 (each within the scatter of the next).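

In this assay, the exchange of 3-methylphenyl for 4-methylphenyl on a sulfonyl sulfur comes to a 1.0-fold higher number from compound 1 to compound 3 (0.01 log units; within the scatter). Among these compounds, this is the first comparison here of compounds differing in one place, and on these figures the two methylphenyl groups cannot be told apart at this position. Nothing further is available that bears on this result. Still open, as far as these compounds go, is whether the same holds for a group without the methyl, such as plain phenyl, or for a different one, such as pyridyl or methoxyphenyl. From the compounds shown here alone, the effect of changes elsewhere on the shared core also remains open.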